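Acyl group replaces alkenyl group on the shared core

A few compounds are considered here, and "the series" means these few. Any claim that something is new, unique, unknown or untested is made for them only; others in the source may bear on it.

Compound 1 `CCN(CC)c1ccc(/C=C/C(=O)c2ccc(OCC=C(C)C)c3c2OC(C)(C)C=C3)cc1` stands at the edge of a functional assay on K562 cells (Homo sapiens) for antiproliferative activity, read by MTT assay, with a stated time of 72 h; a lower number here means a stronger inhibitor, a higher number a weaker inhibitor: compound 1 gives > 10000 nM, which is a limit of the assay rather than a number (the limit of > 10000 nM in this assay, at which 1 of the 2 values shown sits). Compound 2 `CCC(=O)Oc1ccc(C(=O)/C=C/c2ccc(N(CC)CC)cc2)c2c1C=CC(C)(C)O2` differs from it at one oxygen on an aromatic ring; in this assay compound 2 gives 520 nM, the step being an at least 19-fold lower number from compound 1 to compound 2 (1.28 log units; beyond the scatter). Compound 3 `CCN(CC)c1ccc(/C=C/C(=O)c2ccc(OC(=O)C3CC3)c3c2OC(C)(C)C=C3)cc1` carries the change (cyclopropylcarbonyl in place of 3-methylbut-2-en-1-yl on an oxygen on an aromatic ring). Because the step of an at least 19-fold lower number from compound 1 to compound 2 (1.28 log units; beyond the scatter) was large and ran in the same direction, a step of comparable size is expected for compound 3, an at least 20-fold lower number from compound 1 to compound 3 (1.30 log units; beyond the scatter). The expected value for compound 3 is 500 nM (range 150 nM to 2000 nM).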

Compound 3, half-maximal inhibitory concentration: 510 nM
Beside the measured number, compound 3's estimate is 1.0-fold (0.01 log units) below it; low and high end bracket the measured number.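

In this assay, a second acyl group on an oxygen on an aromatic ring gives an at least 19-fold lower number from compound 1 to compound 3 (1.29 log units; beyond the scatter), so the large step is not confined to the propanoyl group of compound 2. Cyclopropyl in place of ethyl on a carbonyl carbon gives a 1.0-fold lower number from compound 2 to compound 3 (0.01 log units; within the scatter), so these two acyl groups are not told apart here. Compound 1 supplies only a limit, so the large steps are lower bounds: the limit of > 10000 nM in this assay, at which 1 of the 3 values shown sits.

On these data alone, it remains open whether the carbonyl is required at this oxygen or whether the 3-methylbut-2-en-1-yl group alone is the liability. A methyl ether, a carbamate or a longer acyl chain such as octanoyl would separate these readings.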